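The source may report more compounds than this note shows. Statements on the series, on what has been measured and on what is new or still open speak of the compounds shown alone.

Compound 1 `COc1cc2c(Oc3ccc(NC(=O)c4nn(-c5ccccc5C)c(=O)cc4C)cc3F)ccnc2cc1OCCCN1CCCCC1` gives 2500 nM in a functional assay on U-87MG ATCC cells (Homo sapiens) for inhibition, read by MTT assay, with a stated time of 72 h; a lower number here means a stronger inhibitor, a higher number a weaker inhibitor. Compound 2 `COc1cc2c(Oc3ccc(NC(=O)c4nn(-c5ccccc5C)c(=O)cc4C)cc3F)ccnc2cc1OCCCN1CCC(C)CC1` differs from it by methyl in place of hydrogen on a saturated ring carbon; in this assay compound 2 gives 2240 nM, a step of a 1.1-fold lower number from compound 1 to compound 2 (0.05 log units; within the scatter). Compound 4 `COc1cc2c(Oc3ccc(NC(=O)c4nn(-c5cccc(F)c5)c(=O)cc4C)cc3F)ccnc2cc1OCCCN1CCC(C)CC1` is not yet measured and stands to compound 3 `COc1cc2c(Oc3ccc(NC(=O)c4nn(-c5cccc(F)c5)c(=O)cc4C)cc3F)ccnc2cc1OCCCN1CCCCC1` as compound 2 stands to compound 1: the change is methyl in place of hydrogen on a saturated ring carbon, the same kind of change, with the place described in the same words. The two cores differ by 3-fluorophenyl in place of 2-methylphenyl on an aromatic nitrogen; in this assay compound 3 gives 1500 nM, a step of a 1.7-fold lower number from compound 1 to compound 3 (0.22 log units; within the scatter). Because the earlier methyl step was a 1.1-fold lower number from compound 1 to compound 2 (0.05 log units; within the scatter), the step expected for compound 4 is a 1.1-fold lower number from compound 3 to compound 4 (0.03 log units; within the scatter). The estimate for compound 4 in this assay is 1400 nM, expected to fall between 750 nM and 2600 nM.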

Compound 4, half-maximal inhibitory concentration: 1800 nM
For compound 4 the middle estimate is 1.3-fold (0.11 log units) below the measured one; the range from low to high includes it.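

In this assay the change from piperidin-1-yl to 4-methylpiperidin-1-yl on the core of compound 3 gives a 1.2-fold higher number from compound 3 to compound 4 (0.08 log units; within the scatter) and matches the same change on the core of compound 1: the same change on two cores in this assay, a 1.1-fold lower number (0.05 log units; within the scatter) from compound 1 to compound 2 and a 1.2-fold higher number (0.08 log units; within the scatter) from compound 3 to compound 4, 1.3-fold (0.13 log units) apart, within the scatter of two such steps. The aryl change, read on the 4-methylpiperidin-1-yl pair, gives a 1.2-fold lower number from compound 2 to compound 4 (0.09 log units; within the scatter) and also carries over: the same change on two cores in this assay, a 1.7-fold lower number (0.22 log units; within the scatter) from compound 1 to compound 3 and a 1.2-fold lower number (0.09 log units; within the scatter) from compound 2 to compound 4, 1.3-fold (0.13 log units) apart, within the scatter of two such steps. Every step here lies within the scatter, so the two changes appear to carry between these two cores, but this does not show that either change has a real effect in this assay, or that the match holds on any other core.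

Only piperidin-1-yl and 4-methylpiperidin-1-yl appear as the amine group, with 2-methylphenyl and 3-fluorophenyl on the aromatic nitrogen. From the compounds shown here alone, whether a dimethylamino group, a carboxylic acid or a longer chain in place of the methyl would give a step beyond the scatter remains open.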